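Aryl Variation on the Amine Substituent in Receptor Binding

The source may hold more compounds than are shown below. What is called first, only, known or untested is meant among the compounds shown, and "the series" means these compounds.

Compound 1 `CN(Cc1cccs1)C1CCN(CCCc2c[nH]c3ccc(-n4cnnc4)cc23)CC1`, compound 2 `CC(C)=CCN(C)C1CCN(CCCc2c[nH]c3ccc(-n4cnnc4)cc23)CC1` and compound 3 `CN(Cc1ccco1)C1CCN(CCCc2c[nH]c3ccc(-n4cnnc4)cc23)CC1` share one core and differ only in the group on a saturated chain carbon bound to an amine nitrogen. In an assay on CHO cells for displacement of a labelled ligand from 5-hydroxytryptamine receptor 1B (Homo sapiens) (a lower number here means a stronger inhibitor, a higher number a weaker inhibitor), compound 1 gives 140 nM, compound 2 gives 41 nM and compound 3 gives 89 nM. Compound 3 thus has the second highest of the three numbers, with compound 1 nearest, within the scatter, and compound 2 furthest. Compound 4 `CC(=O)Nc1ccc(CN(C)C2CCN(CCCc3c[nH]c4ccc(-n5cnnc5)cc34)CC2)cc1` carries 4-acetamidophenyl in place of furan-2-yl on a saturated chain carbon bound to an amine nitrogen. Within the data shown here, the steps at this place so far were a 1.6-fold lower number from compound 1 to compound 3 (0.20 log units; within the scatter) and a 2.2-fold higher number from compound 2 to compound 3 (0.34 log units; beyond the scatter), both modest at most. Among the measured compounds shown here, no measured step covers a group like the entering one, so compound 4 is expected to show a 1.1-fold higher number from compound 3 to compound 4 (0.05 log units; within the scatter). Compound 4 is therefore estimated at 100 nM, between 35 nM and 300 nM.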

Compound 4, half-maximal inhibitory concentration: 100 nM
The estimate for compound 4 equals the measured number at the digits printed; the range from low to high includes it.
By their numbers in this assay, from the lowest: compound 2; then compounds 3, 4 and 1 (each within the scatter of the next).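

In this assay, a six-membered aromatic ring of carbon only that carries a hydrogen-bond donor can stand at this place in place of furan-2-yl without leaving the scatter (a 1.1-fold higher number from compound 3 to compound 4 (0.05 log units; within the scatter)). The same holds against thiophen-2-yl (a 1.4-fold lower number from compound 1 to compound 4 (0.15 log units; within the scatter)), whereas 2-methylprop-1-en-1-yl remains apart (a 2.4-fold higher number from compound 2 to compound 4 (0.39 log units; beyond the scatter)), so among these four compounds only compound 2 lies beyond the scatter of the others. No supporting data bear on why the number responds in this way.

As far as these compounds go, whether the amide hydrogen matters stays open, as does whether an amine or a carboxylic acid in place of the acetamido group would move the number.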